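Compound 4: a five-membered lactam ring in place of six

This account rests on a few compounds, and the source may have more. Where it says the series, first, only, none or still open, it means among the compounds named here.

Measured in a functional assay on CHO cells for antagonist activity at prostaglandin E2 receptor EP3 subtype (Homo sapiens), read by cAMP accumulation; on this read-out higher numbers stand for weaker inhibition and lower numbers for stronger inhibition:
- compound 1 `CC(C)C(c1ccc(-c2ccc3cccc(F)c3c2)[nH]c1=O)N1CCCCC1=O`: 40 nM
- compound 2 `CC(C)C(Nc1nccs1)c1ccc(-c2ccc3cccc(F)c3c2)[nH]c1=O`: 10 nM
- compound 3 `CC(C)C(c1ccc(-c2ccc3cccc(F)c3c2)[nH]c1=O)N1CCNC1=O`: 28 nM

Compound 1 has the highest number of the three in this assay; its nearest neighbour is compound 3, with a 1.4-fold lower number from compound 1 to compound 3 (0.15 log units; within the scatter), and its furthest is compound 2, with a 4.0-fold lower number from compound 1 to compound 2 (0.60 log units; beyond the scatter). Compound 4 `CC(C)C(/C=C1/CCNC1=O)c1ccc(-c2ccc3cccc(F)c3c2)[nH]c1=O` differs from compound 1 by a group of 7 heavy atoms (5 carbon, 1 nitrogen, 1 oxygen; one five-membered non-aromatic ring with 1 hetero atom) in place of a group of 7 heavy atoms (5 carbon, 1 nitrogen, 1 oxygen; one six-membered non-aromatic ring with 1 hetero atom), on a saturated chain carbon bound to an aromatic carbon and a saturated chain carbon. Going by the values given here, two measured steps bear on this. Swapping 2-oxopiperidin-1-yl for 2-oxoimidazolidin-1-yl gave a 1.4-fold lower number from compound 1 to compound 3 (0.15 log units; within the scatter), while swapping it for (1,3-thiazol-2-yl)amino gave a 4.0-fold lower number from compound 1 to compound 2 (0.60 log units; beyond the scatter). Since the entering group keeps a lactam carbonyl and a hydrogen-bond donor, compound 4 is expected to sit close to compound 1, with at most a small step of a 1.3-fold lower number from compound 1 to compound 4 (0.12 log units; within the scatter). Compound 4 is therefore estimated at 30 nM, within 10 nM to 90 nM.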

Compound 4, half-maximal inhibitory concentration: 8.1 nM
For compound 4 the middle estimate is 3.7-fold (0.57 log units) above the measured one, and the stated range ends above it.
By their numbers in this assay, from the lowest: compounds 4 and 2 (each within the scatter of the next); then compounds 3 and 1 (each within the scatter of the next).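

In this assay, a lactam at this position is not tied to the level of the first two lactam-type groups: the five-membered ring carrying a hydrogen-bond donor gave a 4.9-fold lower number from compound 1 to compound 4 (0.69 log units; beyond the scatter) and a 3.5-fold lower number from compound 3 to compound 4 (0.54 log units; beyond the scatter). Its gap to the (1,3-thiazol-2-yl)amino group, a 1.2-fold lower number from compound 2 to compound 4 (0.09 log units; within the scatter), shows that an aromatic ring is not needed at this place to reach that level. Nothing available gives a cause for these steps.

Ring size, the added double bond and the hydrogen-bond donor all change together, so their separate shares remain open. On these data alone, how a carboxylic acid or a simple amine would read on this saturated chain carbon also remains open.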